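A few compounds are considered here, and "the series" means these few. Any claim that something is new, unique, unknown or untested is made for them only; others in the source may bear on it.

Compound 1 `COc1cc(/C=C/C(=O)Nc2ccccc2)ccc1OCCCN1CCCCC1` and compound 2 `COc1cc(/C=C/C(=O)Nc2ccccc2)ccc1OCCCN1CCCC1` share a core and differ only in the ring at the end of the chain: pyrrolidin-1-yl in place of piperidin-1-yl on a saturated chain carbon, three bonds along the chain from an oxygen on an aromatic ring. In a physicochemical assay for lipophilicity, using the shake flask method, measured as octanol-water partition, at pH 7.4 (a higher number here means a more lipophilic compound, a lower number a more polar compound), compound 1 gives 1.58, and compound 2 gives 1.57, so the step of a number 0.01 log units lower from compound 1 to compound 2 (within the scatter) is too small to count as a change. Compound 3 `COc1cc(/C=C/C(=O)Nc2ccccc2)ccc1OCCCCN1CCCCC1` carries the longer chain; its core differs from that of compound 1 as (piperidin-1-yl)methyl in place of piperidin-1-yl on a saturated chain carbon, three bonds along the chain from an oxygen on an aromatic ring, and in this assay compound 3 gives 1.61. Compound 4 `COc1cc(/C=C/C(=O)Nc2ccccc2)ccc1OCCCCN1CCCC1` has not yet been measured. The change from compound 3 to compound 4 is pyrrolidin-1-yl in place of piperidin-1-yl on a saturated chain carbon, four bonds along the chain from an oxygen on an aromatic ring, the same kind of change as from compound 1 to compound 2, but here the place is four bonds along the chain from the oxygen on the aromatic ring rather than three. Since that earlier change moved the number by a number 0.01 log units lower from compound 1 to compound 2 (within the scatter), the step from compound 3 to compound 4 is expected to be about a number 0.01 log units lower from compound 3 to compound 4 (within the scatter). Compound 4 is therefore estimated at 1.6 in this assay.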

Compound 4, partition coefficient: 1.6
Compound 4: middle estimate and measured number agree at the digits printed; the measured number falls inside the stated range.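

In this assay the swap of piperidin-1-yl for pyrrolidin-1-yl on the longer chain gives a step of a number 0.01 log units lower from compound 3 to compound 4 (within the scatter), and the same swap on the shorter chain gave a step of a number 0.01 log units lower from compound 1 to compound 2 (within the scatter), so on these two cores the change carries over as no change that stands out from the scatter. The two steps that lengthen the chain read the same way, one a number 0.03 log units higher from compound 2 to compound 4 (within the scatter) and the other a number 0.02 log units higher from compound 1 to compound 4 (within the scatter), which leaves all four compounds within the scatter of one another. This does not show that the swap would stay this small on a core further removed from these two, and no measurement at hand offers an explanation for the result.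

Still open, going by these compounds, is how other end groups on these chains would read, such as morpholine or a dimethylamino group, and how a longer chain would read. Also open, on these data alone, is whether a carboxylic acid or a chlorine placed on the shared core would leave this swap just as small.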